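This account rests on a few compounds, and the source may have more. Where it says the series, first, only, none or still open, it means among the compounds named here.

In a functional assay on the whole organism for inhibition, with Cavia porcellus as the target (a lower number here means that less compound is needed, a higher number that more compound is needed for the effect), three compounds built on one shared core have been measured. Compound 1 (`COc1ccccc1OCC1SCCN1C(C)=O`) gives 46 mg/kg. Compound 2 (`COc1ccccc1OCC1SCCN1C(=O)CC(=O)N1CCN(C)CC1`) gives 27 mg/kg, and compound 3 (`COc1ccccc1OCC1SCCN1C(=O)CC(=O)N1CCN(Cc2ccccc2)CC1`) gives 41 mg/kg. Compound 3 thus stands within the scatter of both compound 1 and compound 2, and the three values cannot be told apart.

Compound 4 (`COc1ccccc1OCC1SCCN1C(=O)CC(=O)N1CCN(C(c2ccccc2)c2ccccc2)CC1`) has not yet been measured. It departs from compound 3 through one change, phenyl in place of hydrogen on a saturated chain carbon bound to an amine nitrogen in a ring and an aromatic carbon.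

The closest measured precedent is a 1.5-fold higher number from compound 2 to compound 3 (0.18 log units; within the scatter), where phenyl likewise took the place of hydrogen on a saturated chain carbon. The other measured step, a 1.7-fold lower number from compound 1 to compound 2 (0.23 log units; within the scatter), is a different change and bears on this one only loosely. Neither step left the scatter, so neither supports expecting a larger move here, although two steps are thin evidence. The expected step, a 1.0-fold lower number from compound 3 to compound 4 (0.01 log units; within the scatter), is therefore none beyond the scatter. Compound 4 is estimated at 40 mg/kg, with an expected range from 20 mg/kg to 80 mg/kg.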

Compound 4, dose for half-maximal effect: 66 mg/kg
Estimate against measurement, compound 4: 1.7-fold (0.22 log units) below; measured number inside the range.
By their numbers in this assay, from the lowest: compounds 2, 3, 1 and 4 (each within the scatter of the next, the first and the last beyond it).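

In this assay the phenyl on a saturated chain carbon bound to an amine nitrogen in a ring and an aromatic carbon gives a 1.6-fold higher number from compound 3 to compound 4 (0.21 log units; within the scatter) and so leaves this step, like a 1.5-fold higher number from compound 2 to compound 3 (0.18 log units; within the scatter) before it, inside the scatter. Yet the two steps point the same way, and compound 2 at 27 mg/kg and compound 4 at 66 mg/kg lie beyond the scatter of each other, a separation that none of the earlier compounds showed, so compound 4 has the higher number of that pair even though no single step at this position stands out. Nothing measured here offers an explanation for this result.

The compounds shown leave open whether a methyl group in place of the entering phenyl on this carbon, or a phenyl carrying a chlorine or a methoxy group, would give a number that stands with compound 3 or with compound 4. They also leave open whether a carboxylic acid or an amine on this chain would separate from compound 2 in a single step.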